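Restoring an Ester Group on the Shared Core

The compounds below may be only part of what the source reports. "The series", "measured", "known", "first", "only" and "open" are said of these compounds alone.

Compound 1 `CCOC(=O)c1cccc(-c2ccc(OCC)cc2)c1` gives 87% in an assay on COS-7 cells for inhibition of patatin-like phospholipase domain-containing protein 2 (Mus musculus), tested at 200 uM; on this read-out lower numbers stand for less inhibition and higher numbers for more inhibition at the one concentration tested (going by the name of the read-out).
Compound 2 `CCNS(=O)(=O)c1cccc(-c2ccc(OCC)cc2)c1` gives 46% in this assay.
Compound 3 `CCOc1ccc(-c2ccccc2)cc1` gives 35% in this assay.

Compound 3 stands lowest of the three: the step of a number 52 percentage points lower from compound 1 to compound 3 (beyond the scatter) and the step of a number 11 percentage points lower from compound 2 to compound 3 (beyond the scatter) both end at it. Compound 4 `CCCCOC(=O)c1cccc(-c2ccc(OCC)cc2)c1` differs from compound 3 by butoxycarbonyl in place of hydrogen on an aromatic carbon. The step that bears most directly on this change is a number 52 percentage points lower from compound 1 to compound 3 (beyond the scatter), a large loss when ethoxycarbonyl gave way to hydrogen on that aromatic carbon; the step of a number 41 percentage points lower from compound 1 to compound 2 (beyond the scatter) shows that ethylsulfamoyl did not hold the number up as well. Butoxycarbonyl is the nearest relative of ethoxycarbonyl among these compounds, so a large rise is expected. Compound 4 is expected to give 80%, between 55% and 95%, an expected step of a number 45 percentage points higher from compound 3 to compound 4 (beyond the scatter).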

Compound 4, a percentage reported as inhibition, at one concentration (the size of the read-out at that concentration, not a potency): 61%
The estimate for compound 4 lay 19 percentage points above the measured number, and the stated range covers the measured number.
By their numbers in this assay, from the lowest: compound 3; then compound 2; then compound 4; then compound 1.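

Butoxycarbonyl recovers only part of what the loss of the ester cost: in this assay it brings a number 26 percentage points higher from compound 3 to compound 4 (beyond the scatter) and, against the sulfonamide, a number 15 percentage points higher from compound 2 to compound 4 (beyond the scatter). Extending the ester chain gives a number 26 percentage points lower from compound 1 to compound 4 (beyond the scatter), so at this position the chain on the ester counts, not just the presence of a carbonyl group. Nothing at hand explains this difference. Still open, on these data alone, is where a methyl ester, the free carboxylic acid or a primary amide would fall at this position. As far as these compounds go, a branched chain such as isopropyl is equally open.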